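Piperidine replaces thiomorpholine in a thiosemicarbazide series

The source may hold more compounds than are shown below. What is called first, only, known or untested is meant among the compounds shown, and "the series" means these compounds.

Measured compounds:
compound 1 `Cc1ccnc(/C(N)=N/NC(=S)N2CCSCC2)c1`: 79.6%
compound 2 `N/C(=N\NC(=S)N1CCSCC1)c1ccccn1`: 80.8%
compound 3 `Cc1ccnc(/C(N)=N/NC(=S)N2CCCCCC2)c1`: 71%

In a functional assay on A-431 cells (Homo sapiens) for cytotoxicity, read by MTT assay, with a stated time of 72 h, tested at 100 uM (on this read-out lower numbers stand for less inhibition of growth and higher numbers for more inhibition of growth at the one concentration tested), compound 1 gives 79.6%, the second highest of the three numbers, although its distances to compound 2 and to compound 3 both lie within the scatter. Within the data shown here, the one step measured in one place, a number 1.2 percentage points higher from compound 1 to compound 2 (within the scatter), changes the aromatic substituent, not the ring on the thiocarbonyl carbon. Compound 4 `Cc1ccnc(/C(N)=N/NC(=S)N2CCCCC2)c1` differs from compound 1 by piperidin-1-yl in place of thiomorpholin-4-yl on a thiocarbonyl carbon. Among the measured compounds shown here, no measured step alters this ring alone; compound 3, with a seven-membered ring in that place, gives 71%, close to compound 1. For compound 4 an estimate of 76% is therefore expected, between 64% and 88%, a change of a number 3.6 percentage points lower from compound 1 to compound 4 (within the scatter) that is expected to stay within the scatter.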

Compound 4, percent growth inhibition at one concentration: 77.6%
Compound 4: middle estimate off by 1.6 percentage points, on the low side; measured number inside the range.
By their numbers in this assay, from the lowest: compounds 3, 4, 1 and 2 (each within the scatter of the next).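

In this assay, among these compounds, the change at the thiocarbonyl carbon gives a number 2 percentage points lower from compound 1 to compound 4 (within the scatter), the first step to alter this ring alone. Piperidin-1-yl, which has no ring sulfur and no hydrogen-bond acceptor, thus leaves the number within the scatter, so the ring sulfur of thiomorpholin-4-yl is not shown to matter at this one concentration. No evidence bears on why this is so.

Still open, from the compounds shown here alone, is how morpholin-4-yl, 4-methylpiperazin-1-yl or an open-chain dimethylamino group would read on the same carbon. Also open, going by these compounds, is whether the swap holds without the methyl on the aromatic carbon.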